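Swapping the urea aryl group: compound 2 to compound 3

The source may hold more compounds than are shown below. What is called first, only, known or untested is meant among the compounds shown, and "the series" means these compounds.

Compound 1 `O=C(Nc1cccc(-c2cnc3c(NC(=O)c4cc(Cl)cc(Cl)c4)nccn23)c1)c1ccc(Cl)c(C(F)(F)F)c1` gives 1810 nM in a functional assay on HCT-116 cells (Homo sapiens) for antiproliferative activity, read by CellTiter-Glo, with a stated time of 72 h; on this read-out lower numbers stand for stronger inhibition and higher numbers for weaker inhibition.
Compound 2 `O=C(Nc1cccc(-c2cnc3c(NC(=O)c4cc(Cl)cc(Cl)c4)nccn23)c1)Nc1ccc(F)cc1F` gives 880 nM in this assay.

Among the compounds with values here, on these two numbers compound 2 stands lowest, with compound 1 giving a 2.1-fold lower number from compound 1 to compound 2 (0.31 log units; beyond the scatter) as the only measured step. Compound 3 `O=C(Nc1cccc(-c2cnc3c(NC(=O)c4cc(Cl)cc(Cl)c4)nccn23)c1)Nc1ccc(Cl)c(C(F)(F)F)c1` keeps the urea linkage of compound 2 but carries 4-chloro-3-(trifluoromethyl)phenyl in place of 2,4-difluorophenyl on an amide-type nitrogen. Within the data shown here, that aryl group is the one found in compound 1, yet compound 1 joins it through an amide rather than a urea, so the one measured step changes two things at once and bears only loosely on the step from compound 2 to compound 3. Among the measured compounds shown here, with no step that isolates the aryl swap alone, the expectation for compound 3 is a modest rise in number, somewhere between the two measured values, with a 1.5-fold higher number from compound 2 to compound 3 (0.17 log units; within the scatter) expected. Compound 3 is thus estimated at 1300 nM in this assay, within a range from 500 nM to 3400 nM.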

Compound 3, half-maximal inhibitory concentration: 9510 nM
Compound 3: the middle estimate sits 7.3-fold (0.86 log units) below what was measured; measured number outside the range, above it.
By their numbers in this assay, from the lowest: compound 2; then compound 1; then compound 3.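

In this assay, the group on the amide-type nitrogen of the urea proves to matter a great deal: with the urea kept, 4-chloro-3-(trifluoromethyl)phenyl in place of 2,4-difluorophenyl gives an 11-fold higher number from compound 2 to compound 3 (1.03 log units; beyond the scatter), a large change from one swap. The linkage also counts on its own: with 4-chloro-3-(trifluoromethyl)phenyl held fixed, turning the amide into a urea gives a 5.3-fold higher number from compound 1 to compound 3 (0.72 log units; beyond the scatter), so the earlier step, a 2.1-fold lower number from compound 1 to compound 2 (0.31 log units; beyond the scatter), combined a linkage change that raises the number with an aryl change that lowers it by more. Nothing available here explains why either change has the effect it does.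

The compounds shown carry only two aryl groups on the urea, and these differ in several substituents at once, so the share of the chlorine, the trifluoromethyl and the fluorines stays unresolved. A plain phenyl, a methoxyphenyl or a cyclohexyl on the same nitrogen could help separate those shares, while an amide carrying 2,4-difluorophenyl would show whether the linkage change has a similar effect with that aryl group.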